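Dimethylamino in place of dipropylamino: expected cytotoxicity

The compounds below may be only part of what the source reports. "The series", "measured", "known", "first", "only" and "open" are said of these compounds alone.

Compound 1 `CCOC(=O)CN(C)CC#Cc1cc2c(Nc3ccc(OCc4cccc(F)c4)c(Cl)c3)ncnc2s1`: > 50 uM in an ADME assay on NIH3T3 cells (Mus musculus) for cytotoxicity; on this read-out lower numbers stand for higher toxicity in this test and higher numbers for lower toxicity in this test
Compound 2 `CC(C)(C)CC#Cc1cc2c(Nc3ccc(OCc4cccc(F)c4)c(Cl)c3)ncnc2s1`: > 50 uM
Compound 3 `CCCN(CC#Cc1cc2c(Nc3ccc(OCc4cccc(F)c4)c(Cl)c3)ncnc2s1)CCC`: 2.2 uM

In this assay compound 1 reaches only the limit of > 50 uM and not a number. Compound 2 likewise stops at the limit of > 50 uM. Compound 3 gives 2.2 uM and is the only compound with a number shown. For compounds 1 and 2 only limits are shown, as the limit of > 50 uM in this assay, at which 2 of the 3 values shown sit, records. The two steps that reach compound 3 are therefore large: an at least 22-fold lower number from compound 1 to compound 3 (1.35 log units; beyond the scatter) and an at least 22-fold lower number from compound 2 to compound 3 (1.35 log units; beyond the scatter), while a step that the two limits leave unreadable from compound 1 to compound 2 cannot be read from the two limits.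

Compound 4 `CN(C)CC#Cc1cc2c(Nc3ccc(OCc4cccc(F)c4)c(Cl)c3)ncnc2s1` differs from compound 3 by dimethylamino in place of dipropylamino on a saturated chain carbon bound to a triple-bonded carbon. Both groups that sit at the limit in this assay were replaced by dipropylamino to give the large steps toward compound 3, so the change to the shorter dimethylamino in compound 4 is expected to move the number back upward, though the size is uncertain. For compound 4 the step of a 9.1-fold higher number from compound 3 to compound 4 (0.96 log units; beyond the scatter) is expected, giving an estimate of 20 uM in this assay, within 5 uM to 60 uM.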

Compound 4, half-maximal toxic concentration: 41 uM
Compound 4: middle estimate off by 2.1-fold (0.31 log units), on the low side, within the range that was stated.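

In this assay, the change from dipropylamino to dimethylamino alone gives a 19-fold higher number from compound 3 to compound 4 (1.27 log units; beyond the scatter), which shows that an amine on this saturated chain carbon does not by itself bring the low number of compound 3. Against the other two compounds the result gives an at least 1.2-fold lower number from compound 2 to compound 4 (0.08 log units; that floor lies within the scatter) and an at least 1.2-fold lower number from compound 1 to compound 4 (0.08 log units; that floor lies within the scatter), so neither step shows a difference from compound 4. Both of these steps are read against a limit and not against a number: the limit of > 50 uM in this assay, at which 2 of the 4 values shown sit.

Going by these compounds, how diethylamino, with chains of a length between the two tested here, or a ring amine such as morpholine would read at this place remains open. On these data alone, it is also open whether the step from dipropylamino to dimethylamino would hold with a group other than the 3-fluorobenzyl ether on the shared core.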